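A few compounds are considered here, and "the series" means these few. Any claim that something is new, unique, unknown or untested is made for them only; others in the source may bear on it.

Compound 2 `COc1cccc(CNCCCNc2ccnc3cc(Cc4ccc(C#N)cc4)ccc23)c1O` is one of three measured compounds sharing a single core. In a physicochemical assay for acid dissociation, compound 2 gives 9.47, while compound 1 `COc1ccc(F)cc1CNCCCNc1ccnc2cc(Cc3ccc(C#N)cc3)ccc12` gives 9.47 and compound 3 `N#Cc1ccc(Cc2ccc3c(NCCCNCc4ccco4)ccnc3c2)cc1` gives 9.47, so compound 2 stands level with both. The steps among them, no change at the digits printed from compound 1 to compound 2 (within the scatter) and no change at the digits printed from compound 2 to compound 3 (within the scatter), all concern a group on a saturated chain carbon bound to an amine nitrogen, and none of them moved the number. Compound 4 `COc1cccc(CNCCCNc2ccnc3cc(CCc4ccccc4)ccc23)c1O` is not yet measured and differs from compound 2 elsewhere: benzyl in place of 4-cyanophenyl on a saturated chain carbon bound to an aromatic carbon. Within the data shown here, none of the measured steps touches this part of the molecule, so they bear on it only indirectly. The expected step for compound 4 is a number 0.03 log units higher from compound 2 to compound 4 (within the scatter), nothing beyond the scatter. Compound 4 is estimated at 9.5, between 9.1 and 9.9.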

Compound 4, acid dissociation constant: 9.47
Estimate against measurement, compound 4: 0.03 log units above, within the range that was stated.
By their numbers in this assay, from the lowest: compounds 1, 2, 3 and 4 (each within the scatter of the next).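

In this assay, among these compounds, the earlier steps all changed the group on a saturated chain carbon bound to an amine nitrogen, while this change, benzyl in place of 4-cyanophenyl on a saturated chain carbon bound to an aromatic carbon, gives no change at the digits printed from compound 2 to compound 4 (within the scatter). The read-out therefore also holds when the nitrile leaves and 4-cyanobenzyl becomes phenethyl, a second place in the molecule where a swap leaves the number where it was. Nothing available explains this result. From the compounds shown here alone, whether an amine or a carboxylic acid in place of benzyl would leave the number equally unmoved remains open.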